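The source may hold more compounds than are shown below. What is called first, only, known or untested is meant among the compounds shown, and "the series" means these compounds.

Working notes on the series. In a functional assay on A549 cells (Homo sapiens), read by MTT assay, with a stated time of 3 days (a lower number here means a stronger inhibitor, a higher number a weaker inhibitor), compound 1 (`CN(C)c1ncnc2[nH]cc(Sc3cccs3)c12`) gives 19800 nM and compound 2 (`CNc1ncnc2[nH]cc(Sc3cccs3)c12`) gives 28600 nM while compound 3 (`Nc1ncnc2[nH]cc(Sc3cccs3)c12`) gives 22800 nM and so stands within the scatter of both others.

Compound 4 (`c1csc(Sc2c[nH]c3ncnc(-c4cccs4)c23)c1`) has thiophen-2-yl in place of amino on an aromatic carbon and keeps the rest of the core of compound 3.

The measured steps that bear on this carbon are a 1.4-fold higher number from compound 1 to compound 2 (0.16 log units; within the scatter) and a 1.2-fold higher number from compound 1 to compound 3 (0.06 log units; within the scatter) as well as a 1.3-fold lower number from compound 2 to compound 3 (0.10 log units; within the scatter) and all of them lie within the scatter. Across these three compounds, methyl on the nitrogen makes no difference beyond the scatter. All three steps keep a nitrogen on this carbon, however. Going by the values given here, the data hold no measured compound with a ring there, so these steps are only a weak guide to the change at hand and give no direction for it.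

No step beyond the scatter is therefore expected, though with wide uncertainty. The estimated move is a 1.3-fold lower number from compound 3 to compound 4 (0.10 log units; within the scatter) in this assay for now. Compound 4 is expected at 18000 nM with an estimated range from 6000 nM to 50000 nM until it is measured.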

Compound 4, half-maximal inhibitory concentration: 16200 nM
The estimate for compound 4 lay 1.1-fold (0.05 log units) above the measured number; measured number inside the range.
By their numbers in this assay, from the lowest: compounds 4, 1, 3 and 2 (each within the scatter of the next).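

Going by these compounds alone, a ring now stands on this aromatic carbon, where the earlier compounds carried only a nitrogen. In this assay thiophen-2-yl in place of amino gives a 1.4-fold lower number from compound 3 to compound 4 (0.15 log units; within the scatter) and in place of methylamino gives a 1.8-fold lower number from compound 2 to compound 4 (0.25 log units; within the scatter) while in place of dimethylamino it gives a 1.2-fold lower number from compound 1 to compound 4 (0.09 log units; within the scatter) and so none of the three steps passes the scatter. This position, next to the ring nitrogen, therefore takes thiophen-2-yl, with 5 heavy atoms and 0 hydrogen-bond donors, in place of amino, with 1 heavy atom and 1 hydrogen-bond donor, without a step beyond the scatter, and no measurement at hand explains why the numbers stay so close.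

Open, going by these compounds, is whether any group on this carbon gives a step beyond the scatter, for instance a phenyl ring, a saturated amine such as morpholine or a carboxylic acid. Also open, on these data alone, is what a change elsewhere would do, since the sulfur link and its thiophene stay the same in all four compounds, so a phenyl ring or a methyl group in place of that thiophene remains an untested question in these data.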